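Moving the Trifluoromethyl Group in a Diaryl Urea Series

This account rests on a few compounds, and the source may have more. Where it says the series, first, only, none or still open, it means among the compounds named here.

Compound 1: `COc1cc2cc(Oc3ccc(NC(=O)Nc4ccc(C)cc4)cc3)c(C)nc2cc1OC`, 101%
Compound 2: `COc1cc2cc(Oc3ccc(NC(=O)Nc4ccc(C(F)(F)F)cc4)cc3)c(C)nc2cc1OC`, 68.5%

In a functional assay on CCRF-CEM cells (Homo sapiens) for inhibition, read by sulforhodamine B assay, with a stated time of 48 h, tested at 10 uM (a higher number here means a weaker effect of the compound at the concentration tested, a lower number a stronger effect), compound 1 gives 101%, and compound 2 gives 68.5%. Compound 2 stands lowest of the two numbers shown; its nearest neighbour is compound 1, and the step of a number 32.5 percentage points lower from compound 1 to compound 2 (beyond the scatter) separates them. Compound 3, `COc1cc2cc(Oc3ccc(NC(=O)Nc4cccc(C(F)(F)F)c4)cc3)c(C)nc2cc1OC`, has not yet been measured. It differs from compound 2 by 3-(trifluoromethyl)phenyl in place of 4-(trifluoromethyl)phenyl on an amide-type nitrogen. Going by the values given here, the one measured step, a number 32.5 percentage points lower from compound 1 to compound 2 (beyond the scatter), concerns a different kind of change, an exchange of one group for another, and so does not bear directly on relocating the trifluoromethyl within the ring. Among the compounds with values here, no step of that kind is in hand. Compound 3 is therefore expected to stay close to compound 2 in this assay. For compound 3 the expected step is a number 1.5 percentage points higher from compound 2 to compound 3 (within the scatter), not beyond the scatter. The estimate for compound 3 is 70%, ranging from 45% to 95%.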

Compound 3, a percentage reported as activity, at one concentration (the size of the read-out at that concentration, not a potency): 6.41%
Compound 3: middle estimate off by 63.6 percentage points, on the high side, outside the stated range (below it).
By their numbers in this assay, from the lowest: compound 3; then compound 2; then compound 1.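

In this assay, the place of the trifluoromethyl on the phenyl ring carried by the amide-type nitrogen matters in its own right: 3-(trifluoromethyl)phenyl in place of 4-(trifluoromethyl)phenyl gives a number 62.1 percentage points lower from compound 2 to compound 3 (beyond the scatter), with the same atoms joined differently. Replacing the 4-methylphenyl of compound 1 with this group gives a number 94.6 percentage points lower from compound 1 to compound 3 (beyond the scatter), and the larger share of that step comes with the move rather than with the exchange of methyl for trifluoromethyl. Nothing available accounts for the size of this effect.

The compounds shown leave open whether a chlorine, a nitrile or a methoxy group in place of the trifluoromethyl of compound 3 would hold this effect. Since each read-out comes from one concentration, they also give no potency for compound 3.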